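The compounds below may be only part of what the source reports. "The series", "measured", "known", "first", "only" and "open" are said of these compounds alone.

Measured in a functional assay on PC-12 cells (Rattus norvegicus) for cytotoxicity, read by MTT assay, with stated times of 2 h and 24 h, tested at 5 uM; on this read-out lower numbers stand for a weaker effect and higher numbers for a stronger effect at the one concentration tested:
compound 1 `Cc1ccc(-n2nc(-c3ccc(C(F)(F)F)cc3O)nc2-c2ccccc2O)cc1` gives 94.1%
compound 2 `Oc1cc(C(F)(F)F)ccc1-c1nc(-c2ccccc2O)n(-c2ccccc2F)n1` gives 86.6%
compound 3 `Oc1cc(C(F)(F)F)ccc1-c1nc(-c2ccccc2O)n(-c2cccc(C(F)(F)F)c2)n1` gives 92.2%

Of the three numbers compound 3 holds the second highest, yet all three lie within the scatter of one another: nearest is compound 1 with a number 1.9 percentage points lower from compound 1 to compound 3 (within the scatter), furthest is compound 2 with a number 5.6 percentage points higher from compound 2 to compound 3 (within the scatter).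

Compound 4 `Oc1cc(C(F)(F)F)ccc1-c1nc(-c2ccccc2O)n(-c2cc(C(F)(F)F)cc(C(F)(F)F)c2)n1` is the next member. It differs from compound 3 in one place: trifluoromethyl in place of hydrogen on an aromatic carbon.

Every step measured so far changes the group on the aromatic nitrogen, and every one of them stayed within the scatter: a number 7.5 percentage points lower from compound 1 to compound 2 (within the scatter), a number 1.9 percentage points lower from compound 1 to compound 3 (within the scatter) and a number 5.6 percentage points higher from compound 2 to compound 3 (within the scatter). Among the measured compounds shown here, none of them adds a second trifluoromethyl to a ring that already bears one, so the present change has no exact precedent, but the shared core has so far kept its read-out within a narrow band whatever the group on the nitrogen. No step beyond the scatter is therefore expected for compound 4, whose step from compound 3 is estimated as a number 2.2 percentage points lower from compound 3 to compound 4 (within the scatter). Compound 4 is expected to give about 90%, within a range of 78% to 98%.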

Compound 4, a percentage reported as activity, at one concentration (the size of the read-out at that concentration, not a potency): 75.7%
Compound 4: the middle estimate sits 14.3 percentage points above what was measured; measured number outside the range, below it.
By their numbers in this assay, from the lowest: compound 4; then compounds 2, 3 and 1 (each within the scatter of the next).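

In this assay, trifluoromethyl in place of hydrogen on an aromatic carbon, meta to a trifluoromethyl group, gives a number 16.5 percentage points lower from compound 3 to compound 4 (beyond the scatter), the only step shown that lies beyond the scatter. The earlier steps shown here all changed the group on the aromatic nitrogen and stayed within the scatter, so the narrow band held by compounds 1, 2 and 3 does not extend to this second trifluoromethyl, although compound 4 still gives 75.7% at the one concentration tested. No measurement at hand bears on why the read-out differs at this position.

Open, as far as these compounds go, is whether this step belongs to trifluoromethyl itself or to any group on that carbon. An amine, a methoxy group or a carboxylic acid at the same place would help separate these two readings.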